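Swapping a Hydroxyphenyl for a Methoxyphenyl on the Sulfonamide

The compounds below may be only part of what the source reports. "The series", "measured", "known", "first", "only" and "open" are said of these compounds alone.

Three sulfonamides have been tested in an assay on isolated protein for inhibition of malate dehydrogenase, mitochondrial (Sus scrofa), with stated times of 45 min and 30 min; on this read-out lower numbers stand for stronger inhibition and higher numbers for weaker inhibition. Compound 1 `COc1ccccc1S(=O)(=O)Nc1ccc2oc(-c3ccccc3)nc2c1` gives only the limit of this assay, > 63000 nM. Compound 2 `O=S(=O)(Nc1ccc(-c2nc3ccccc3o2)cc1)c1ccccc1O` likewise stops at the limit, > 63000 nM. Compound 3 `Cc1cccc(S(=O)(=O)Nc2ccc3oc(-c4ccccc4)nc3c2)c1` also returns nothing but the limit, > 63000 nM. For the measured compounds named here, the one measured pair that differs in a single place, the step from compound 1 to compound 3, is a step that the two limits leave unreadable from compound 1 to compound 3, so its size cannot be read. Compound 2 thus stands at the weak end of what this assay can report, without a number of its own; (the limit of > 63000 nM in this assay, at which 3 of the 3 values shown sit). Compound 4 `COc1cccc(S(=O)(=O)Nc2ccc(-c3nc4ccccc4o3)cc2)c1` has not yet been measured. It differs from compound 2 by 3-methoxyphenyl in place of 2-hydroxyphenyl on a sulfonyl sulfur. Going by the values given here, no measured step covers an exchange of this kind, and the only recorded step is unreadable, so no direction can be drawn for the change in this assay, and compound 4 is expected to sit at the limit as well. The expected step is a number no higher from compound 2 to compound 4 (the limit leaves the size open). Compound 4 is therefore estimated at 63000 nM, within a range from 20000 nM to 200000 nM.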

Compound 4, half-maximal inhibitory concentration: > 63000 nM
Compound 4 was reported as a limit (the forecaster's own chance of this, stated with the estimate: 85%); the middle value lies on the limit itself.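

Compound 2 and compound 4 are both reported only as limits, so the step between them cannot be read: the limit of > 63000 nM in this assay, at which 4 of the 4 values shown sit. The compounds shown leave open whether any group on the sulfonyl sulfur can give a measured number rather than a limit.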